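A few compounds are considered here, and "the series" means these few. Any claim that something is new, unique, unknown or untested is made for them only; others in the source may bear on it.

Compound 1 `COC1=C(OC)[C@H](O)[C@H](C/C=C(\C)CC/C=C(\C)C[C@@H]2C[C@@H](C)C(=O)O2)[C@@H](C)C1=O` gives 14100 nM in a functional assay on A549 cells (Homo sapiens) for inhibition, read by sulforhodamine B assay, with a stated time of 48 h (on this read-out higher numbers stand for weaker inhibition of growth and lower numbers for stronger inhibition of growth), a number that sits second highest of the three measured, though within the scatter of both neighbours: compound 2 `COC1=C(OC)[C@H](O)[C@H](C/C=C(\C)CC/C=C(\C)C[C@H](O)/C=C(\C)CO)[C@@H](C)C1=O` gives 12000 nM and compound 3 `COC1=C(OC)[C@H](O)[C@H](C/C=C(\C)CC/C=C(\C)C/C=C/C(C)(C)O)[C@@H](C)C1=O` gives 23800 nM. The steps of a 1.2-fold lower number from compound 1 to compound 2 (0.07 log units; within the scatter) and a 1.7-fold higher number from compound 1 to compound 3 (0.23 log units; within the scatter) both swap the group on a saturated chain carbon bound to a double-bonded chain carbon, and neither touches the hydroxy on the core. Compound 4 `COC1=C(OC)[C@H](OC(C)=O)[C@H](C/C=C(\C)CC/C=C(\C)C[C@@H]2C[C@@H](C)C(=O)O2)[C@@H](C)C1=O` differs from compound 1 by acetyl in place of hydrogen on an oxygen on a saturated carbon. Among the compounds with values here, no measured step bears on that oxygen, so there is no ground to expect a step beyond the scatter in this assay. Compound 4 is therefore expected to give 14000 nM, in a range from 5000 nM to 40000 nM, an expected step of a 1.0-fold lower number from compound 1 to compound 4 (0.00 log units; within the scatter).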

Compound 4, concentration for 50% growth inhibition: 11300 nM
For compound 4 the middle estimate is 1.2-fold (0.09 log units) above the measured one; measured number inside the range.
By their numbers in this assay, from the lowest: compounds 4, 2, 1 and 3 (each within the scatter of the next, the first and the last beyond it).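

Acetyl in place of hydrogen on the oxygen gives a 1.2-fold lower number from compound 1 to compound 4 (0.10 log units; within the scatter) in this assay, so this oxygen, which no earlier compound varied, takes an acetoxy group with no step beyond the scatter. For this one change, then, the free hydroxy on the core is not needed to keep the number within the scatter of compound 1. Nothing at hand explains this result.

On these data alone, whether a methyl ether, a longer acyl chain or an amine at this place would behave alike remains open. So does whether hydroxy to acetoxy reads the same with the side chains of compound 2 and compound 3.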